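A few compounds are considered here, and "the series" means these few. Any claim that something is new, unique, unknown or untested is made for them only; others in the source may bear on it.

Measured so far in a physicochemical assay for lipophilicity, at pH 7.4; on this read-out higher numbers stand for higher lipophilicity and lower numbers for lower lipophilicity:
- compound 1 `CCc1ccc(N(C2CCC2)S(=O)(=O)c2ccc3c(c2)C(O)CC(C2CCOCC2)O3)cc1`: 3.69
- compound 2 `Cc1ccc(N(C2CCC2)S(=O)(=O)c2ccc3c(c2)C(O)CC(C2CCOCC2)O3)c(C)c1`: 3.77
- compound 3 `CCc1ccc(N(CC(C)C)S(=O)(=O)c2ccc3c(c2)CCC3OC2CCOCC2)cc1`: 4.96

Compound 1 and compound 2 sit together at the low end of these numbers, while the value of compound 3 lies well apart from both, beyond the scatter. The next compound to be measured, compound 4 `CCc1ccc(NS(=O)(=O)c2ccc3c(c2)C(O)CC(C2CCOCC2)O3)cc1`, carries hydrogen in place of cyclobutyl on a sulfonamide nitrogen.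

Among the compounds with values here, only one measured step changes a single place, a number 0.08 log units higher from compound 1 to compound 2 (within the scatter). That step swaps 2,4-dimethylphenyl for 4-ethylphenyl and leaves the cyclobutyl untouched, so it gives little guidance on size here. Compound 3 differs from compound 1 in several places and offers no clean comparison. Within the data shown here, the data therefore hold no direct precedent for this change.

The expectation rests on the structural change alone: carbon leaves and only hydrogen enters, which suggests a clear move downward. The expected size is a number 0.94 log units lower from compound 1 to compound 4 (beyond the scatter). For compound 4 the estimate is 2.75, with an expected range from 2.25 to 3.25.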

Compound 4, distribution coefficient: 2.59
For compound 4 the middle estimate is 0.16 log units above the measured one; low and high end bracket the measured number.
By their numbers in this assay, from the lowest: compound 4; then compounds 1 and 2 (each within the scatter of the next); then compound 3.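

In this assay, hydrogen in place of cyclobutyl on the sulfonamide nitrogen gives a number 1.10 log units lower from compound 1 to compound 4 (beyond the scatter), so the read-out responds strongly to what sits at this spot in the shared core. Within the data shown here, the one earlier single-place step, with 2,4-dimethylphenyl in place of 4-ethylphenyl, gave a number 0.08 log units higher from compound 1 to compound 2 (within the scatter) and left the cyclobutyl untouched, so it could not show what removing that group does. Nothing at hand explains the size of this new step.

Only cyclobutyl and hydrogen can be compared cleanly at this nitrogen, so two points cannot tell whether the number falls steadily as carbon is removed or changes mainly once the nitrogen carries hydrogen. From the compounds shown here alone, a small methyl group would help to separate those two readings, and it remains open how a chain ending in an amine or a carboxylic acid would behave here.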